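Cyano for chloro on a triazole-linked coumarin ether

This account rests on a few compounds, and the source may have more. Where it says the series, first, only, none or still open, it means among the compounds named here.

Compounds measured in a functional assay on A549 cells (Homo sapiens) for cytotoxicity, read by MTT assay, with a stated time of 48 h; a higher number here means a weaker inhibitor, a lower number a stronger inhibitor:
- compound 3, `O=c1ccc2cc(OCc3cn(-c4ccccc4Cl)nn3)ccc2o1`: 17100 nM
- compound 1, `O=c1ccc2cc(OCc3cc(-c4ccccc4)no3)ccc2o1`: "not determined" (no result reported)
- compound 2, `O=c1ccc2cc(OCc3cc(-c4cccc5ccccc45)no3)ccc2o1`: "not determined" (no result reported)

Among the measured compounds shown here, compound 3 is the only compound of the three with a number in this assay; for compound 1 the entry reads "not determined" (no result reported), and for compound 2 the entry reads "not determined" (no result reported), so nothing can be said about how they compare. The value of compound 3 marks it as a weak inhibitor in this assay, and it stands alone as the only reference point.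

Compound 4, `N#Cc1ccccc1-n1cc(COc2ccc3oc(=O)ccc3c2)nn1`, differs from compound 3 in one place: cyano in place of chloro on an aromatic carbon. Apart from this exchange the two share the same core and the same linker.

For the measured compounds named here, no step between measured compounds is available, so there is no measured precedent for how this assay responds to such an exchange. The expectation for compound 4 is a step of a 1.2-fold higher number from compound 3 to compound 4 (0.07 log units; within the scatter), that is, no change beyond the usual scatter. Compound 4 is therefore estimated at 20000 nM, with a range from 7000 nM to 60000 nM.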

Compound 4, half-maximal inhibitory concentration: 12600 nM
Beside the measured number, compound 4's estimate is 1.6-fold (0.20 log units) above it; the measured number falls inside the stated range.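

In this assay, cyano in place of chloro on an aromatic carbon, ortho to a large group, gives a 1.4-fold lower number from compound 3 to compound 4 (0.13 log units; within the scatter). Among the compounds shown here, this is the first measured step at this position, where the earlier compounds offered only a single number, and it shows that the change from 2-chlorophenyl to 2-cyanophenyl does not move the read-out beyond the usual scatter. Nothing at hand explains this outcome.

On these data alone, it remains open whether an amine, a carboxylic acid or a methoxy group at this same place would shift the number beyond the scatter. As far as these compounds go, compound 1 and compound 2 have no number in this assay, so it also remains open how their aryl groups and different linker would compare with the two measured compounds.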